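This account rests on a few compounds, and the source may have more. Where it says the series, first, only, none or still open, it means among the compounds named here.

Measured so far in a physicochemical assay for lipophilicity, at pH 7.4; a lower number here means a more polar compound, a higher number a more lipophilic compound:
- compound 1 `Cc1[nH]c2ccccc2c(=O)c1Cc1ccccc1`: 1.93
- compound 2 `CCCCC#Cc1c(C)[nH]c2ccccc2c1=O`: 5.44
- compound 3 `COc1cccc2c(=O)c(Cc3ccccc3)c(C)[nH]c12`: 2.24

Compound 3 holds the second highest of these three values. Its nearest neighbour is compound 1, and compound 2 lies furthest away, well above it.

The next structure is compound 4 `Cc1[nH]c2c(Cl)cccc2c(=O)c1Cc1ccccc1`, with chloro in place of methoxy on an aromatic carbon.

Among the measured compounds shown here, one measured step bears on this change: a number 0.31 log units higher from compound 1 to compound 3 (beyond the scatter). It is modest but beyond the scatter, and it comes from methoxy in place of hydrogen on an aromatic carbon. For the measured compounds named here, no measured compound carries chloro, so the exchange itself has no direct precedent. Compound 2 differs from the others in another place and offers no guide here.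

A modest upward step in this assay is therefore expected, of similar order to a number 0.31 log units higher from compound 1 to compound 3 (beyond the scatter). The expected change is a number 0.41 log units higher from compound 3 to compound 4 (beyond the scatter). For compound 4 the estimate is 2.65, with an expected range from 2.2 to 3.1.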

Compound 4, distribution coefficient: 2.78
Estimate against measurement, compound 4: 0.13 log units below; low and high end bracket the measured number.
By their numbers in this assay, from the lowest: compound 1; then compound 3; then compound 4; then compound 2.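

In this assay, one aromatic carbon of the shared core can now be read with three substituents: hydrogen in compound 1, methoxy in compound 3 and chloro in compound 4. Methoxy is not the upper end at this position, since chloro in its place gives a further rise (a number 0.54 log units higher from compound 3 to compound 4 (beyond the scatter)) and chloro in place of hydrogen gives the largest step at this carbon (a number 0.85 log units higher from compound 1 to compound 4 (beyond the scatter)). Nothing measured here explains this order of hydrogen, methoxy and chloro.

On these data alone, whether an amine or a carboxylic acid on this aromatic carbon would fall below compound 1 remains open. Also open, as far as these compounds go, is whether chloro on another aromatic carbon of the core would give a step of similar size.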